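This account rests on a few compounds, and the source may have more. Where it says the series, first, only, none or still open, it means among the compounds named here.

Measured so far in a functional assay on HEK293 cells for agonist activity at Bile acid receptor (Homo sapiens); on this read-out higher numbers stand for an effect only at larger amounts of compound and lower numbers for an effect already at smaller amounts:
compound 1 `CC(C)c1onc(-c2c(Cl)cccc2Cl)c1COc1ccc(NC(=O)c2ccc(C(=O)O)cc2)c(C(F)(F)F)n1`, 474 nM;
compound 2 `CC(C)c1onc(-c2c(Cl)cccc2Cl)c1COc1ccc(N(C)Cc2cccc(C(=O)O)c2)c(C(F)(F)F)n1`, 80 nM.

Within the data shown here, compound 2 gives the lower of the two numbers in this assay; the one measured step, a 5.9-fold lower number from compound 1 to compound 2 (0.77 log units; beyond the scatter), is the whole distance between them. Compound 3 `CC(C)c1onc(-c2c(Cl)cccc2Cl)c1COc1ccc(N(C)Cc2cccc(C(=O)NS(C)(=O)=O)c2)c(C(F)(F)F)n1` differs from compound 2 by methanesulfonamido in place of hydroxy on a carbonyl carbon. Among the measured compounds shown here, no measured step touches the acid group itself; the step from compound 1 to compound 2 changed the linker to the shared core and does not bear on this change. With nothing directly comparable, compound 3 is expected to remain close to compound 2, an estimated 1.5-fold higher number from compound 2 to compound 3 (0.18 log units; within the scatter). The estimate for compound 3 is 120 nM, expected range 40 nM to 400 nM.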

Compound 3, half-maximal effective concentration: 279 nM
Beside the measured number, compound 3's estimate is 2.3-fold (0.37 log units) below it, within the range that was stated.
By their numbers in this assay, from the lowest: compound 2; then compounds 3 and 1 (each within the scatter of the next).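

In this assay, among these compounds, the first measured step at the acid group itself, carboxy to (methylsulfonyl)carbamoyl, gives a 3.5-fold higher number from compound 2 to compound 3 (0.54 log units; beyond the scatter), so the number responds to what sits on this carbonyl carbon. Agonist activity is kept with methanesulfonamido in place of hydroxy, though only at larger amounts of compound. Nothing available here accounts for the shift.

Open, going by these compounds, is whether an unsubstituted carboxamide or a trifluoromethanesulfonamido group on this carbonyl carbon would stay closer to compound 2. Also open, on these data alone, is whether the same replacement would give a similar step on the linker of compound 1.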